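A few compounds are considered here, and "the series" means these few. Any claim that something is new, unique, unknown or untested is made for them only; others in the source may bear on it.

compound 1 `CN(C)CCCCCn1c2c(c3ccccc31)C(=O)c1c[n+]([O-])c3ccccc3c1C2=O` gives 240 nM
compound 2 `O=C1c2c[n+]([O-])c3ccccc3c2C(=O)c2c1c1ccccc1n2CCN1CCCCC1` gives 1050 nM
compound 3 `CN1CCN(CCCCCn2c3c(c4ccccc42)C(=O)c2c[n+]([O-])c4ccccc4c2C3=O)CC1` gives 1640 nM

These values come from a toxicity assay on L02 cells (Homo sapiens) for cytotoxicity, read by MTT assay, with a stated time of 72 h; on this read-out lower numbers stand for stronger inhibition and higher numbers for weaker inhibition. Compound 3 stands with compound 2 at the weaker end of this small set, as a 1.6-fold higher number from compound 2 to compound 3 (0.19 log units; within the scatter) shows. It lies clearly away from compound 1, as a 6.8-fold higher number from compound 1 to compound 3 (0.83 log units; beyond the scatter) shows.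

Compound 4 `O=C1c2c[n+]([O-])c3ccccc3c2C(=O)c2c1c1ccccc1n2CCCN1CCC(O)CC1` has not yet been measured. Its difference from compound 3 is this: 4-hydroxypiperidin-1-yl in place of 2-(4-methylpiperazin-1-yl)ethyl on a saturated chain carbon, three bonds along the chain from an aromatic nitrogen. Cut one bond further out, 5-(4-methylpiperazin-1-yl)pentyl gives way to 3-(4-hydroxypiperidin-1-yl)propyl.

Among the measured compounds shown here, no measured step makes exactly this change. The closest guide is the exchange of one ring-bearing chain end for another, a 1.6-fold higher number from compound 2 to compound 3 (0.19 log units; within the scatter). Moving from the dimethylamino group of compound 1 to a ring-bearing chain end gave larger, modest steps: a 4.4-fold higher number from compound 1 to compound 2 (0.64 log units; beyond the scatter), alongside the step to compound 3 given above. Compound 4 also ends in a ring-bearing group, so it is expected to resemble compound 2 and compound 3 rather than compound 1. For the measured compounds named here, no measured compound carries the hydroxy group, so the range must stay wide.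

In this assay, no shift beyond the scatter is expected, and any movement would most likely be slight, towards a lower number. The expected change is a 1.5-fold lower number from compound 3 to compound 4 (0.17 log units; within the scatter). For compound 4 the estimated value is 1100 nM, with an expected range of 350 nM to 3000 nM.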

Compound 4, half-maximal inhibitory concentration: 120 nM
Beside the measured number, compound 4's estimate is 9.2-fold (0.96 log units) above it; the whole stated range lies above it.
By their numbers in this assay, from the lowest: compounds 4 and 1 (each within the scatter of the next); then compounds 2 and 3 (each within the scatter of the next).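

In this assay, a ring at the chain end does not by itself bring a high number: the 3-(4-hydroxypiperidin-1-yl)propyl end of compound 4 gives a 14-fold lower number from compound 3 to compound 4 (1.14 log units; beyond the scatter), and the comparison with the shorter chain end gives an 8.8-fold lower number from compound 2 to compound 4 (0.94 log units; beyond the scatter). Compound 4 also sits within the scatter of the open dimethylamino end, with a 2.0-fold lower number from compound 1 to compound 4 (0.30 log units; within the scatter), so these two cannot be told apart here. The earlier compounds shown here suggested that ring-bearing ends go with the higher numbers, but that reading now holds only for compound 2 and compound 3, and compound 4 goes against it.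

No supporting measurement explains this large fall in the number, so its cause remains unknown. Compound 4 differs from compound 3 in both the ring end and the chain length, which leaves open how much each contributes, and a 3-(piperidin-1-yl)propyl or 3-(morpholin-4-yl)propyl end would help to separate the effect of the hydroxy group from that of the chain.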